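Swapping a pyrazinyl cap for methyl on the piperazine

A few compounds are considered here, and "the series" means these few. Any claim that something is new, unique, unknown or untested is made for them only; others in the source may bear on it.

For the measured compounds named here, compound 2 `Nc1ccccc1NC(=O)c1ccc(CSC(=S)N2CCN(c3cnccn3)CC2)cc1` stands highest of the two compounds measured so far. In a functional assay on HeLa cells (Homo sapiens) for antiproliferative activity, read by CCK-8 assay, with a stated time of 72 h, tested at 2 uM (on this read-out higher numbers stand for a stronger effect at the one concentration tested and lower numbers for a weaker effect), compound 2 gives 70.4%, while compound 1 `Nc1ccccc1NC(=O)c1ccc(CSC(=S)N2CCN(c3ncccn3)CC2)cc1` gives 52.2%. Going by the values given here, the single measured step, a number 18.2 percentage points higher from compound 1 to compound 2 (beyond the scatter), shows that this position on the shared core can shift the read-out beyond the scatter. Compound 3 `CN1CCN(C(=S)SCc2ccc(C(=O)Nc3ccccc3N)cc2)CC1` differs from compound 2 in methyl in place of pyrazin-2-yl on an amine nitrogen in a ring. Among the compounds with values here, no measured step pairs an aromatic ring against a methyl at this position, so the step from compound 1 to compound 2 only hints that the position matters, not which way this change will go. A moderate drop is expected, so compound 3 is estimated at 55%, within a range from 30% to 78%, corresponding to an expected step of a number 15.4 percentage points lower from compound 2 to compound 3 (beyond the scatter).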

Compound 3, a percentage reported as inhibition, at one concentration (the size of the read-out at that concentration, not a potency): 52.6%
Compound 3: middle estimate off by 2.4 percentage points, on the high side, within the range that was stated.
By their numbers in this assay, from the lowest: compounds 1 and 3 (each within the scatter of the next); then compound 2.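

In this assay, replacing the pyrazin-2-yl group with a methyl gives a number 17.8 percentage points lower from compound 2 to compound 3 (beyond the scatter), so the higher number of compound 2 does not survive when this aromatic ring is reduced to a single carbon. The comparison with the other aromatic ring gives a number 0.4 percentage points higher from compound 1 to compound 3 (within the scatter), which means that methyl and pyrimidin-2-yl cannot be told apart here, and that carrying an aromatic ring at this nitrogen does not by itself raise the read-out. Nothing measured here explains why pyrazin-2-yl stands apart from the other two groups.

As far as these compounds go, it remains open whether this advantage is specific to pyrazin-2-yl or would extend to other aromatic rings, such as a pyridin-2-yl or a phenyl ring. It is also unknown how a longer chain such as ethyl or propyl would compare with methyl at this nitrogen.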